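Methyl for Trifluoromethyl: What to Expect of Compound 4

A few compounds are considered here, and "the series" means these few. Any claim that something is new, unique, unknown or untested is made for them only; others in the source may bear on it.

Measured so far in a functional assay on HeLa cells (Homo sapiens) for antiproliferative activity, with a stated time of 24 h; on this read-out higher numbers stand for weaker inhibition and lower numbers for stronger inhibition:
compound 1 `NC(=O)c1c(NC(=O)c2ccc(C(F)(F)F)cc2)sc2c1CCN(C(=S)Nc1ccccc1Cl)C2`: 44000 nM
compound 2 `Cc1ccc(C(=O)Nc2sc3c(c2C(N)=O)CCN(C(=S)Nc2ccccc2Cl)C3)cc1`: 26300 nM
compound 3 `NC(=O)c1c(NC(=O)c2ccccc2Br)sc2c1CCN(C(=S)Nc1ccccc1C(F)(F)F)C2`: 39600 nM

Compound 4 `Cc1ccccc1NC(=S)N1CCc2c(sc(NC(=O)c3ccccc3Br)c2C(N)=O)C1` has not yet been measured in this assay.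

Compound 1 and compound 2 differ in one place: methyl in place of trifluoromethyl on an aromatic carbon. That change gave a 1.7-fold lower number from compound 1 to compound 2 (0.22 log units; within the scatter). Compound 4 differs from compound 3 by the same exchange: methyl in place of trifluoromethyl on an aromatic carbon. The surroundings are not identical, though: in the first pair the changed carbon is para to a large group, in the second it is ortho to a large group, so this is the same kind of change rather than the same change. The difference between the core of compound 3 and the core of compound 1 is not broken down here. Compound 1 with 44000 nM and compound 3 with 39600 nM lie within the scatter of each other.

The expectation rests on compound 3 giving 39600 nM and on the small size of a 1.7-fold lower number from compound 1 to compound 2 (0.22 log units; within the scatter). A step of a 1.3-fold lower number from compound 3 to compound 4 (0.12 log units; within the scatter) is therefore expected. Compound 4 is estimated to give 30000 nM, likely between 15000 nM and 60000 nM.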

Compound 4, half-maximal inhibitory concentration: > 50000 nM
Compound 4: only a limit was reported; the forecaster's own chance of this, stated with the estimate: 10%; middle value at least 1.6-fold (0.22 log units) away from the limit.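

In this assay compound 4 returned only a limit of the assay, not a number: the limit of > 50000 nM in this assay, at which 1 of the 4 values shown sits.

What can be read from this result is therefore only a floor for the new step, an at least 1.2-fold higher number from compound 3 to compound 4 (0.10 log units; that floor lies within the scatter), and even that floor gives no firm sign of any change in this assay. Set beside the earlier pair, this does not show that methyl in place of trifluoromethyl carries over from one core to the other, nor does it show that the exchange behaves differently on the two cores: the same change on two cores in this assay, a 1.7-fold lower number (0.22 log units; within the scatter) from compound 1 to compound 2 and an at least 1.2-fold higher number (0.10 log units; that floor lies within the scatter) from compound 3 to compound 4; the limit leaves it open whether they differ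

The compounds shown leave open what other groups on these aromatic rings would do in this assay, for example an amine, a carboxylic acid or a longer chain. Also open, going by these compounds, is what the exchange does at one and the same place on two different cores, as the two pairs differ in both the core and the place of the change.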